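The source may hold more compounds than are shown below. What is called first, only, known or untested is meant among the compounds shown, and "the series" means these compounds.

In a functional assay on a cell-free system (Platelet, plasma, Oryctolagus cuniculus) for inhibition, with a stated time of 5 min, at 37 degrees C (on this read-out higher numbers stand for weaker inhibition and lower numbers for stronger inhibition), compound 3 `Cc1nc(C)c(C(=O)Oc2ccc(/C=C/C(=O)O)cc2O)nc1C` gives 84600 nM, compound 1 `CCOC(=O)/C=C/c1ccc(OC(=O)c2nc(C)c(C)nc2C)c(O)c1` gives 77400 nM, and compound 2 `Cc1nc(C)c(C(=O)Oc2cccc(/C=C/C(=O)O)c2)nc1C` gives 26400 nM, the lowest number of the three, with both other compounds standing beyond the scatter above it. Between compound 3 and compound 1 the change is ethyl in place of hydrogen on an oxygen next to a carbonyl group, and the step was a 1.1-fold lower number from compound 3 to compound 1 (0.04 log units; within the scatter). The difference between the core of compound 2 and the core of compound 3 is not broken down here. Compound 4 `CCOC(=O)/C=C/c1cccc(OC(=O)c2nc(C)c(C)nc2C)c1` is not yet measured; it arises from compound 2 by ethyl in place of hydrogen on an oxygen next to a carbonyl group, the same change, at the same place, as from compound 3 to compound 1. Because that earlier step was a 1.1-fold lower number from compound 3 to compound 1 (0.04 log units; within the scatter), the step from compound 2 to compound 4 in this assay is expected to be a 1.1-fold lower number from compound 2 to compound 4 (0.04 log units; within the scatter). Compound 4 is therefore estimated at 24000 nM, between 9000 nM and 65000 nM.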

Compound 4, half-maximal inhibitory concentration: 35800 nM
Estimate against measurement, compound 4: 1.5-fold (0.17 log units) below, and the stated range covers the measured number.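

In this assay, ethyl in place of hydrogen on an oxygen next to a carbonyl group gave a 1.4-fold higher number from compound 2 to compound 4 (0.13 log units; within the scatter). On both cores shown, the change from carboxy to ethoxycarbonyl thus left the number within the scatter, and the two steps do not differ from each other: the same change on two cores in this assay, a 1.1-fold lower number (0.04 log units; within the scatter) from compound 3 to compound 1 and a 1.4-fold higher number (0.13 log units; within the scatter) from compound 2 to compound 4, 1.5-fold (0.17 log units) apart, within the scatter of two such steps This shows that the change carried over between these two cores on this read-out, but it does not show that it would carry to any other core, and it gives no reason for the result.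

The compounds shown leave open whether a longer chain in place of ethyl on that oxygen would behave in the same way. They also leave open whether an amide in place of the ester would do so.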